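A Methyl Group Added to a Weak Binder

The source may hold more compounds than are shown below. What is called first, only, known or untested is meant among the compounds shown, and "the series" means these compounds.

Compound 1 `CCc1cccc(CC)c1Nc1nc(C)nc(NCc2ccc(C(F)(F)F)cc2)n1`: 55000 nM in an assay on isolated protein for binding affinity to corticotropin-releasing factor receptor 1 (Homo sapiens); on this read-out lower numbers stand for stronger inhibition and higher numbers for weaker inhibition
Compound 2 `Cc1nc(NCc2ccc(C(F)(F)F)cc2)nc(Nc2c(C)cccc2C)n1`: > 10000 nM

In this assay compound 1 gives 55000 nM. For compound 2 this assay reports only a limit, > 10000 nM. Compound 2 therefore stands at the limit of > 10000 nM in this assay, at which 1 of the 2 values shown sits. The step that the limit leaves unreadable from compound 1 to compound 2 cannot be sized. Compound 3 `Cc1cc(C)c(Nc2nc(C)nc(NCc3ccc(C(F)(F)F)cc3)n2)c(C)c1` differs from compound 2 by methyl in place of hydrogen on an aromatic carbon. Within the data shown here, no measured step sizes such a change, and the one step available is unreadable. Compound 3 is expected to stay in the same weak region, the step that the limit leaves unreadable from compound 2 to compound 3 expected to be within the scatter. Compound 3 is estimated at 20000 nM, ranging from 4000 nM to 100000 nM.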

Compound 3, inhibition constant: 1690 nM
Compound 3: middle estimate off by 12-fold (1.07 log units), on the high side; the whole stated range lies above it.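

In this assay, methyl in place of hydrogen on the aromatic carbon para to a large group gives an at least 5.9-fold lower number from compound 2 to compound 3 (0.77 log units; beyond the scatter), so this position, unread until now, does affect binding. Going from 2,6-diethylphenyl to 2,4,6-trimethylphenyl gives a 33-fold lower number from compound 1 to compound 3 (1.51 log units; beyond the scatter), the first readable gain in the series. The full size of the methyl step remains unknown, since its starting point is only a limit: the limit of > 10000 nM in this assay, at which 1 of the 3 values shown sits.

Left open is whether a chlorine, a methoxy group or a longer chain on this carbon would serve as the methyl does.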